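The compounds below may be only part of what the source reports. "The series", "measured", "known", "first", "only" and "open" are said of these compounds alone.

Measured in a functional assay on PANC-1 cells (Homo sapiens) for inhibition, read by MTT assay, with a stated time of 24 h, tested at 10 uM; on this read-out higher numbers stand for more inhibition at the one concentration tested (going by the name of the read-out) and lower numbers for less inhibition:

compound 1, `CCOc1cc(=O)n(CCCO)c2c1CC(CC=C(C)C)C(C)(C)C2`: 66.5%
compound 2, `COc1ccc(C(=O)NCCCOc2cc(=O)n(CCCO)c3c2CC(CC=C(C)C)C(C)(C)C3)cc1`: 55.5%
compound 3, `COc1ccc(NC(=O)Oc2cc(=O)n(CCCO)c3c2CC(CC=C(C)C)C(C)(C)C3)cc1`: 3.7%

Compound 3 gives the lowest of the three numbers in this assay; compound 2 gives 55.5% and compound 1 gives 66.5%, and both of them stand well beyond the scatter above compound 3. Two steps from compound 1 are known. The step of a number 11 percentage points lower from compound 1 to compound 2 (beyond the scatter) is a modest fall and sits on the saturated chain carbon near the oxygen on the aromatic ring. The step of a number 62.8 percentage points lower from compound 1 to compound 3 (beyond the scatter) is a large fall and sits on that oxygen itself, where the (4-methoxyphenyl)carbamoyl group comes in.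

Compound 4, `CC(C)=CCC1Cc2c(OC(=O)Nc3ccc(F)c(F)c3)cc(=O)n(CCCO)c2CC1(C)C`, is not yet measured. It differs from compound 3 in one place: 3,4-difluorophenyl in place of 4-methoxyphenyl on an amide-type nitrogen. Among the compounds with values here, neither known step touches the amide-type nitrogen, so no measured step bears directly on this change; the data give no reading on swapping one aryl for another at that position. With compound 3 already at the bottom of the range, the step is expected to stay within the scatter, a number 4.3 percentage points higher from compound 3 to compound 4 (within the scatter). Compound 4 is therefore estimated at 8% in this assay, with a range from 0% to 30%.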

Compound 4, a percentage reported as inhibition, at one concentration (the size of the read-out at that concentration, not a potency): 76.7%
Compound 4: the middle estimate sits 68.7 percentage points below what was measured; measured number above the stated range.
By their numbers in this assay, from the lowest: compound 3; then compound 2; then compound 1; then compound 4.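

Within the data shown here, the aryl group on the amide-type nitrogen turns out to control this read-out: in this assay, 3,4-difluorophenyl in place of 4-methoxyphenyl gives a number 73 percentage points higher from compound 3 to compound 4 (beyond the scatter), a change the earlier compounds could not reveal, as none varied this aryl group. The large fall seen with compound 3 therefore does not follow from carbamoyl on the oxygen on the aromatic ring as such, since (3,4-difluorophenyl)carbamoyl in place of ethyl at that oxygen gives a number 10.2 percentage points higher from compound 1 to compound 4 (beyond the scatter), so the swap from ethyl now reads as a modest rise instead of a large fall, with the direction set by the aryl group alone among the compounds shown. Nothing available accounts for this swing between the two aryl groups.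

Among these compounds, with only two aryl groups compared, it remains open whether the methoxy group lowers the number, the two fluorines raise it, or both, and a plain phenyl, a 4-fluorophenyl or a 3-fluorophenyl on the same nitrogen would separate these readings. Also open, as far as these compounds go, is whether a 3,4-difluorophenyl group on the amide chain of compound 2 would give a comparable shift, or whether the effect stays confined to the carbamoyl link.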